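From Compound 2 to Compound 3: An Expected Small Step

This account rests on a few compounds, and the source may have more. Where it says the series, first, only, none or still open, it means among the compounds named here.

Compound 1 `COc1ccc(-c2nc(/N=C(\N)[N+]3(C)CCCCC3)sc2-c2ccc(OC)cc2)cc1`: > 1000 nM (a limit)
Compound 2 `COc1ccc(-c2nc(CNC(=O)N3CCOCC3)sc2-c2ccc(OC)cc2)cc1`: 660 nM

Within the data shown here, in a functional assay with Oryctolagus cuniculus as the target (a higher number here means a weaker inhibitor, a lower number a stronger inhibitor), compound 2 gives 660 nM, the only actual number so far. The entry for compound 1, > 1000 nM, is a limit.

Compound 3 `COc1ccc(-c2nc(C(=O)N=C(N)N)sc2-c2ccc(OC)cc2)cc1` keeps the core of compound 2 and differs from it in one place: a group of 6 heavy atoms (2 carbon, 3 nitrogen, 1 oxygen; no ring) in place of a group of 10 heavy atoms (6 carbon, 2 nitrogen, 2 oxygen; one six-membered non-aromatic ring with 2 hetero atoms), on an aromatic carbon. The change lies on an aromatic carbon of the shared core. Among the measured compounds shown here, only one measured step bears on it, an at least 1.5-fold lower number from compound 1 to compound 2 (0.18 log units; that floor lies within the scatter), which also exchanges a group on an aromatic carbon. That step involves a different pair of groups and gives only a floor, so it sets no firm size or direction. No change beyond the scatter is expected in this assay, and the estimated step is a 1.2-fold higher number from compound 2 to compound 3 (0.08 log units; within the scatter). For compound 3 the estimated value is 800 nM, with an expected range from 200 nM to 3000 nM.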

Compound 3, half-maximal inhibitory concentration: > 100 nM
Compound 3 was reported as a limit (the forecaster's own chance of this, stated with the estimate: 35%); the middle value does not contradict the limit.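

In this assay compound 3 is reported only as a limit, > 100 nM. Among these compounds, no step from compound 1 or compound 2 to compound 3 can be read. The compounds shown leave open whether compound 3 gives a higher or a lower number than compound 2, which carries the (((morpholin-4-yl)carbonyl)amino)methyl group.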